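This account rests on a few compounds, and the source may have more. Where it says the series, first, only, none or still open, it means among the compounds named here.

Series notes. In a functional assay on the whole organism with Rattus norvegicus as the target, at a dose of 3 mg/kg by the oral route (a lower number here means a weaker effect, a higher number a stronger effect of the compound at the dose given), compound 1 `COc1cc(C(=O)Nc2nn[nH]n2)nc(-c2ccccc2)c1` gives 97%. Compound 2 `COc1ccc(-c2cc(OC)cc(C(=O)Nc3nn[nH]n3)n2)cc1` gives 60% in this assay, and compound 3 `Cc1cc(C(=O)Nc2nn[nH]n2)nc(-c2ccccc2)c1` gives 50%; the numbers of compound 2 and compound 3 lie within the scatter of each other. Two changes run from compound 1: methoxy in place of hydrogen on an aromatic carbon gave a number 37 percentage points lower from compound 1 to compound 2 (beyond the scatter), and the cores of compound 1 and compound 3 differ by methyl in place of methoxy on an aromatic carbon, which gave a number 47 percentage points lower from compound 1 to compound 3 (beyond the scatter). Compound 4 `COc1cccc(-c2cc(C)cc(C(=O)Nc3nn[nH]n3)n2)c1` is not yet measured and differs from compound 3 by methoxy in place of hydrogen on an aromatic carbon. This is the same kind of change as that between compound 1 and compound 2, not the same: in compound 2 the entering group is para to a large group, in compound 4 it is meta to a large group. For compound 4 a step of a number 15 percentage points lower from compound 3 to compound 4 (beyond the scatter) is expected in this assay, smaller than the earlier one, because compound 3 already stands at 50% and the cores differ. Compound 4 is estimated at 35%, between 10% and 60%.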

Compound 4, a percentage reported as inhibition, in the whole organism at one dose (the size of the read-out at that dose, not a potency): 65%
For compound 4 the middle estimate is 30 percentage points below the measured one, and the stated range ends below it.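

In this assay methoxy in place of hydrogen on an aromatic carbon gave a number 15 percentage points higher from compound 3 to compound 4 (beyond the scatter) and did not repeat the earlier step; the same change differs between the two cores: the same change on two cores in this assay, a number 37 percentage points lower (beyond the scatter) from compound 1 to compound 2 and a number 15 percentage points higher (beyond the scatter) from compound 3 to compound 4, 52 percentage points apart, beyond the scatter of two such steps

This change therefore cannot be carried from one core to the other as a fixed step in this series. The two pairs also differ in where the methoxy sits, meta to a large group in compound 4 and elsewhere in compound 2, so these steps do not separate the effect of the core from that of the place.

Open, going by these compounds, is whether methoxy at one and the same place on both cores would give steps that agree. Also open, on these data alone, is how a fluoro, a hydroxyl or an ethoxy at that place would read in this assay on either core.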